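The compounds below may be only part of what the source reports. "The series", "measured", "known", "first", "only" and "open" are said of these compounds alone.

Compound 1 `O=c1nc2oc(C3CC3)c(C#CC3CC3)c2cn1Cc1cn(-c2ccccc2F)nn1` carries a cyclopropyl group and a cyclopropylethynyl group on the shared core and a 2-fluorophenyl on the triazole nitrogen. In a functional assay on A549 cells (Homo sapiens) for antiproliferative activity, read by MTT assay, with a stated time of 72 h (on this read-out higher numbers stand for weaker inhibition and lower numbers for stronger inhibition), compound 1 gives 38300 nM. Compound 2 `CCCCCc1ccc(C#Cc2c(-c3ccc(CCCCC)cc3)oc3nc(=O)n(Cc4cn(-c5ccccc5F)nn4)cc23)cc1`, which bears pentylphenyl groups instead, gives 38700 nM in this assay; the two numbers lie within the scatter of each other, so they stand at the same level and neither can be called stronger. Compound 3 `CCCCCCc1cc2cn(Cc3cn(-c4ccccc4F)nn3)c(=O)nc2o1`, with a hexyl chain on the core, reaches only a limit of > 100000 nM in this assay, not a number; (the limit of > 100000 nM in this assay, at which 1 of the 3 values shown sits). Of the two numbers shown, compound 1 thus sits at the same level as compound 2, and compound 3 stands apart only as a limit.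

Compound 4 `O=c1nc2oc(C3CC3)c(C#CC3CC3)c2cn1Cc1cn(Cc2ccccc2)nn1` differs from compound 1 in one place: benzyl in place of 2-fluorophenyl on an aromatic nitrogen. For the measured compounds named here, no measured pair shows this change, so the size of the expected step in this assay has no direct precedent here. Given that compound 1 and compound 2 sit near the same level despite large differences elsewhere, the change on the triazole nitrogen is expected to move the number little, with no step beyond the scatter. Compound 4 is therefore estimated at 45000 nM, with a range from 15000 nM to 100000 nM. This estimate corresponds to an expected step of a 1.2-fold higher number from compound 1 to compound 4 (0.07 log units; within the scatter).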

Compound 4, half-maximal inhibitory concentration: 4810 nM
Compound 4: the middle estimate sits 9.4-fold (0.97 log units) above what was measured; measured number outside the range, below it.
By their numbers in this assay, from the lowest: compound 4; then compounds 1 and 2 (each within the scatter of the next). At a limit, above all of these: compound 3.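

Benzyl in place of 2-fluorophenyl on the aromatic nitrogen gives, in this assay, an 8.0-fold lower number from compound 1 to compound 4 (0.90 log units; beyond the scatter), which shows that what this position carries matters for the read-out. Both groups count the same number of heavy atoms and hold one six-membered aromatic ring of carbon only, yet swapping one for the other still produces a step beyond the scatter. The data shown give no measured property that accounts for this step.

For the compounds shown here, this single pair is the only reading of the position, so it remains open whether the same step would appear with other groups on the shared core. A plain phenyl or a 2-phenylethyl group on the same nitrogen would help to tell apart the part played by the fluorine from the part played by the extra carbon link.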